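Shortening the second chain of compound 1

This account rests on a few compounds, and the source may have more. Where it says the series, first, only, none or still open, it means among the compounds named here.

For the measured compounds named here, compound 1 `C=CCCCCOc1ccccc1-c1cnc(OCCC=C)n1C` holds the lowest of the three numbers so far in a functional assay on MCF7 cells (Homo sapiens) for inhibition, read by colorimetric assay and MTT assay, with a stated time of 72 h; a lower number here means a stronger inhibitor, a higher number a weaker inhibitor: compound 1 gives 8000 nM and is the strongest inhibitor of the set. Compound 2 `C=CCCCCOc1ccc(F)cc1-c1cnc(OCCC=C)n1C` reads 43000 nM and compound 3 `C=CCCOc1ncc(-c2ccccc2OC)n1C` reads 27000 nM in this assay as well.

Compound 4 `C=CCCCCOc1ccccc1-c1cnc(OC)n1C` is still unmeasured. Its structure departs from compound 1 in one place, through the change hydrogen in place of allyl on a saturated chain carbon bound to an oxygen on an aromatic ring so that (but-3-en-1-yl)oxy becomes methoxy. The closest guide is the cut made in the other chain, hydrogen in place of pent-4-en-1-yl, which gave a 3.4-fold higher number from compound 1 to compound 3 (0.53 log units; beyond the scatter) and so a weaker inhibitor. Fluoro in place of hydrogen on an aromatic carbon gave a 5.4-fold higher number from compound 1 to compound 2 (0.73 log units; beyond the scatter) but is a different kind of change and bears less directly. Going by the values given here, nothing measured so far tests the chain altered in compound 4 itself. With only these two steps to go on, both modest and both upward, a modest step to a higher number is expected in this assay for this compound too. The expected step is a 2.8-fold higher number from compound 1 to compound 4 (0.44 log units; beyond the scatter) on this estimate. For compound 4 the estimated value is 22000 nM within an expected range of 9000 nM to 55000 nM overall.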

Compound 4, half-maximal inhibitory concentration: 98000 nM
Beside the measured number, compound 4's estimate is 4.5-fold (0.65 log units) below it, and the stated range ends below it.
By their numbers in this assay, from the lowest: compound 1; then compounds 3 and 2 (each within the scatter of the next); then compound 4.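

Cutting (but-3-en-1-yl)oxy back to methoxy gives, in this assay, a 12-fold higher number from compound 1 to compound 4 (1.09 log units; beyond the scatter) and so a much weaker inhibitor, a large step where the two earlier steps were modest. For the compounds shown here, this is the first measured change to this chain, and it shows that the number for compound 1 depends strongly on the allyl, which accounts for 3 heavy atoms and the one double bond lost here. Nothing available explains why the loss at this position is so large.

The compounds shown do not separate the effect of the chain's length from that of its double bond, so a saturated butyl or propyl chain in this place remains an open comparison. They also leave open whether a longer chain would give a lower number than compound 1, and whether an amine or a carboxylic acid in place of the allyl could keep any of what this change lost.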